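The source may report more compounds than this note shows. Statements on the series, on what has been measured and on what is new or still open speak of the compounds shown alone.

Compound 1 `Cc1ccc2nc(/N=C3\C(=O)N(CN(c4ccccc4)c4ccccc4)c4cccc(Br)c43)sc2c1` was tested in a functional assay on MCF7 cells (Homo sapiens) for cytotoxicity, read by sulforhodamine B assay, with a stated time of 48 h (a higher number here means a weaker inhibitor of growth, a lower number a stronger inhibitor of growth), where compound 1 gives 30200 nM. That is the highest of the two numbers available, and the nearest is compound 2 `CCN(CC)CN1C(=O)/C(=N\c2nc3ccc(C)cc3s2)c2c(Cl)cccc21`, which in this assay gives 19200 nM; the gap between these two lies within the scatter, so nothing separates them. Compound 3 `Cc1ccc2nc(/N=C3\C(=O)N(CN(c4ccccc4)c4ccccc4)c4ccccc43)sc2c1` has not been measured yet. It differs from compound 1 in one place: hydrogen in place of bromo on an aromatic carbon. Among the compounds with values here, no measured pair shows this exact change, so the only footing is the two numbers already in hand, both of them far from potent. The estimated step of a 1.2-fold higher number from compound 1 to compound 3 (0.08 log units; within the scatter) is expected to be none beyond the scatter, leaning if anything toward a higher number. Compound 3 is therefore expected to give about 36000 nM, with a plausible range from 12000 nM to 100000 nM.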

Compound 3, concentration for 50% growth inhibition: 39200 nM
Estimate against measurement, compound 3: 1.1-fold (0.04 log units) below, within the range that was stated.
By their numbers in this assay, from the lowest: compounds 2, 1 and 3 (each within the scatter of the next, the first and the last beyond it).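

In this assay, within the data shown here, the step of a 1.3-fold higher number from compound 1 to compound 3 (0.11 log units; within the scatter) gives the first direct reading of hydrogen in place of bromo on this aromatic carbon. On this shared core, the bromo atom can therefore be removed with no change that stands out from the scatter, so this one comparison gives no sign that the bromo matters for growth inhibition. Nothing available here gives a reason for this result.

Going by these compounds, whether an amine, a methoxy group or a carboxylic acid on the same aromatic carbon would move the number beyond the scatter remains open. On these data alone, compound 2 differs from compound 1 in more than one place, so the effect of each of its differences also remains unknown.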